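Swapping bromo for fluoro on a shared core

The compounds below may be only part of what the source reports. "The series", "measured", "known", "first", "only" and "open" are said of these compounds alone.

Of the compounds shown here, three have been measured so far: compound 1 `COc1ccc(NC(=O)c2csc(-c3cn(Cc4ccc(Cl)cc4)c4ccccc34)n2)cc1`, compound 2 `COc1ccc2[nH]cc(-c3nc(C(=O)Nc4cc(OC)c(OC)c(OC)c4)cs3)c2c1` and compound 3 `COc1cc(NC(=O)c2csc(-c3c[nH]c4ccc(Br)cc34)n2)cc(OC)c1OC`. In a functional assay on LNCaP C4-2 cells (Homo sapiens) for cytotoxicity, read by MTT assay, with a stated time of 48 h, in the presence of a further agent that is not named here (on this read-out lower numbers stand for stronger inhibition and higher numbers for weaker inhibition), compound 1 gives > 100000 nM, which is a limit of the assay rather than a number. Compound 2 likewise gives > 100000 nM, again a limit. Compound 3 gives > 100000 nM, also a limit. Within the data shown here, compound 3 therefore stands where every value so far stands, at the limit of > 100000 nM in this assay, at which 3 of the 3 values shown sit.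

Among the measured compounds shown here, the only pair that differs in one place is compound 2 and compound 3, and their step is a step that the two limits leave unreadable from compound 2 to compound 3; with both ends at a limit, its size cannot be read.

Compound 4 `COc1cc(NC(=O)c2csc(-c3c[nH]c4ccc(F)cc34)n2)cc(OC)c1OC` differs from compound 3 by fluoro in place of bromo on an aromatic carbon. For the measured compounds named here, no measured step bears on this exchange of halogens, and the one measured step is unreadable, so the data give no step beyond the scatter in either direction. The expected step from compound 3 to compound 4 is a number no higher from compound 3 to compound 4 (the limit leaves the size open), that is none beyond the scatter. Compound 4 is therefore estimated at 100000 nM, with a range from 30000 nM to 300000 nM, and is most likely to be reported again as a limit.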

Compound 4, half-maximal inhibitory concentration: > 100000 nM
Compound 4 gave a limit, no number; the forecaster's own chance of this, stated with the estimate: 80%; the middle value sits exactly at the limit.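

In this assay compound 4 gives > 100000 nM, a limit and not a number. No size can be read for the steps linking compound 4 to compound 3 and compound 2, with every value at the same limit: the limit of > 100000 nM in this assay, at which 4 of the 4 values shown sit.

The compounds shown leave open whether bromo, fluoro or methoxy at this place on the shared core makes any difference in this assay.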